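Solubility notes on the oxazole piperidine amide series

The source may report more compounds than this note shows. Statements on the series, on what has been measured and on what is new or still open speak of the compounds shown alone.

Measured compounds, in a physicochemical assay for solubility, in phosphate buffer, measured as kinetic solubility, at pH 7.4; a lower number here means a less soluble compound, a higher number a more soluble compound:
Compound 1 `Cc1oc(-c2ccccc2Cl)nc1CN1CCC(C(=O)NCCCN2C[C@H](C)C[C@H](C)C2)CC1` gives > 72 ug/mL, which is a limit of the assay.
Compound 2 `Cc1ccccc1-c1nc(CN2CCC(C(=O)NCCCN3CCCCC3)CC2)c(C)o1` gives > 65 ug/mL, which is a limit of the assay.
Compound 3 `Cc1ccccc1-c1nc(CN2CCC(C(=O)NCCCCN3C[C@H](C)C[C@H](C)C3)CC2)c(C)o1` gives > 71 ug/mL, which is a limit of the assay.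

Compound 1 stands at a limit only, as do the two other values shown; nothing places it above or below them. Among the compounds with values here, the one computed step, a step that the two limits leave unreadable from compound 2 to compound 3, concerns a different part of the molecule and is left unreadable by its two limits.

Compound 4 `Cc1ccc(-c2nc(CN3CCC(C(=O)NCCCN4C[C@H](C)C[C@H](C)C4)CC3)c(C)o2)c(C)c1` differs from compound 1 by 2,4-dimethylphenyl in place of 2-chlorophenyl on an aromatic carbon. Within the data shown here, no measured step touches this site, so no direction is expected beyond the scatter: a number no higher from compound 1 to compound 4 (the limit leaves the size open) is estimated as flat. Compound 4 is therefore expected to give about 72 ug/mL, between 30 ug/mL and 150 ug/mL, most likely again as a limit.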

Compound 4, solubility: > 71 ug/mL
Compound 4: a limit, no number (the forecaster's own chance of this, stated with the estimate: 65%); the middle value does not contradict the limit.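

Compound 1 and compound 4 both stand only at limits, so no step can be read for 2,4-dimethylphenyl in place of 2-chlorophenyl. The compounds shown leave open how soluble any of them actually is, and whether this change alters solubility at all.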